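A Methoxy Added Again in a Cytotoxicity Series

The source may report more compounds than this note shows. Statements on the series, on what has been measured and on what is new or still open speak of the compounds shown alone.

Of the compounds shown here, three have been measured in a functional assay on 786-0 cells (Homo sapiens) for cytotoxicity, read by sulforhodamine B assay, with a stated time of 48 h, tested at 100 uM; on this read-out lower numbers stand for a stronger effect and higher numbers for a weaker effect at the one concentration tested. Compound 1 `COc1ccc(-c2cc(/C=C/C(=O)c3ccc(N)cc3)[nH]n2)cc1` gives -57%, and compound 3 `COc1ccc(-c2cc(/C=C/C(=O)c3ccc(N)cc3)[nH]n2)cc1OC`, which differs from it by methoxy in place of hydrogen on an aromatic carbon, gives -97%; the step is a number 40 percentage points lower from compound 1 to compound 3 (beyond the scatter). Compound 2 `COc1ccc(C(=O)/C=C/c2cc(-c3cc(OC)c(OC)c(OC)c3)n[nH]2)cc1OC` gives -84% in this assay; the difference between its core and the core of compound 1 is not broken down here. Compound 4 `COc1cc(C(=O)/C=C/c2cc(-c3cc(OC)c(OC)c(OC)c3)n[nH]2)cc(OC)c1OC` has not yet been measured and differs from compound 2 by methoxy in place of hydrogen on an aromatic carbon. Going by the values given here, this is the same kind of change as the one made from compound 1 to compound 3, though not the same: around the new place the entering group is also meta to a methoxy group, which was not so at the earlier place. A step of the earlier size is not expected, because compound 2 already gives -84%, whereas compound 1 set out from -57%. The estimated step in this assay is therefore a number 10 percentage points lower from compound 2 to compound 4 (within the scatter). Compound 4 is expected to give -94% in this assay, with a likely range from -100% to -78%.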

Compound 4, a percentage reported as activity, at one concentration (the size of the read-out at that concentration, not a potency): -98%
Compound 4: middle estimate off by 4 percentage points, on the high side; the range from low to high includes it.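

In this assay, methoxy in place of hydrogen on an aromatic carbon again moves the read-out in the same direction, giving a number 14 percentage points lower from compound 2 to compound 4 (beyond the scatter). The direction of the change therefore carries over from one core to the other in this series, but its size does not: the same change on two cores in this assay, a number 40 percentage points lower (beyond the scatter) from compound 1 to compound 3 and a number 14 percentage points lower (beyond the scatter) from compound 2 to compound 4, 26 percentage points apart, beyond the scatter of two such steps Two pairs cannot show a general rule, and they do not tell whether the difference in size follows from the core, from the surroundings of the place where methoxy enters, or from the different numbers at which the two steps start.

The compounds shown leave open whether another group at this place, such as ethoxy, hydroxy or chlorine, would move the read-out as methoxy does. They also leave open whether the amine of compound 1 and compound 3 would give a similar result on the core of compound 2 if it were replaced by a carboxylic acid or a longer chain.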